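Swapping the aryl ring on the cinnamamide arm of compound 3

The compounds below may be only part of what the source reports. "The series", "measured", "known", "first", "only" and "open" are said of these compounds alone.

Measured compounds:
compound 1, `COc1cc(/C=C/C(=O)Nc2cc3c(Nc4ccc(F)c(Cl)c4)ncnc3cc2O[C@H]2CCOC2)cc(OC)c1O`, 27400 nM
compound 2, `O=C(/C=C/c1cccc(Cl)c1Cl)Nc1cc2c(Nc3ccc(F)c(Cl)c3)ncnc2cc1O[C@H]1CCOC1`, 30500 nM
compound 3, `COc1cc(/C=C/C(=O)Nc2cc3c(Nc4ccc(F)c(Cl)c4)ncnc3cc2O[C@H]2CCOC2)cc(OC)c1`, 34300 nM

In a functional assay on HeLa cells (Homo sapiens) for cytotoxicity, read by MTT assay, with a stated time of 72 h (a lower number here means a stronger inhibitor, a higher number a weaker inhibitor), compound 3 gives 34300 nM, the highest of the three numbers shown, but every gap to the others is within the scatter, so no order among them can be read. The shared core is kept throughout; only the aryl ring on the double-bonded chain carbon changes. Compound 4, `COc1ccc(/C=C/C(=O)Nc2cc3c(Nc4ccc(F)c(Cl)c4)ncnc3cc2O[C@H]2CCOC2)c(OC)c1OC`, differs from compound 3 as follows: 2,3,4-trimethoxyphenyl in place of 3,5-dimethoxyphenyl on a double-bonded chain carbon bound to a double-bonded chain carbon.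

The steps that speak to this change are the earlier ring swaps at the same place, a 1.1-fold higher number from compound 1 to compound 2 (0.05 log units; within the scatter) and a 1.1-fold higher number from compound 2 to compound 3 (0.05 log units; within the scatter), together with the hydroxy removal a 1.3-fold higher number from compound 1 to compound 3 (0.10 log units; within the scatter). All of them lie within the scatter. Because of a 1.1-fold higher number from compound 2 to compound 3 (0.05 log units; within the scatter) the expected step in this assay is a 1.1-fold lower number from compound 3 to compound 4 (0.03 log units; within the scatter), with no movement beyond the scatter. Compound 4 is therefore estimated at 32000 nM, expected between 15000 nM and 65000 nM.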

Compound 4, half-maximal inhibitory concentration: 4830 nM
Beside the measured number, compound 4's estimate is 6.6-fold (0.82 log units) above it; measured number below the stated range.
By their numbers in this assay, from the lowest: compound 4; then compounds 1, 2 and 3 (each within the scatter of the next).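

In this assay, for the compounds shown here, this position proves sensitive to the aryl ring: the earlier swaps stayed within the scatter, whereas 2,3,4-trimethoxyphenyl gives a 7.1-fold lower number from compound 3 to compound 4 (0.85 log units; beyond the scatter) and also a 6.3-fold lower number from compound 2 to compound 4 (0.80 log units; beyond the scatter) and a 5.7-fold lower number from compound 1 to compound 4 (0.75 log units; beyond the scatter), so only this ring among the four stands apart. The 4-hydroxy-3,5-dimethoxyphenyl ring of compound 1 stays within the scatter of compound 3, so adding a further oxygen-bearing group to the 3,5-dimethoxyphenyl ring is not enough on its own. No measurement shown here explains why the 2,3,4-trimethoxyphenyl ring behaves differently.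

Which of its methoxy groups matter remains open. So does how this assay would read with an amine or a longer ether chain in place of one of those methoxy groups.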